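Methyl placed next to the ring nitrogen of compound 1

The source may report more compounds than this note shows. Statements on the series, on what has been measured and on what is new or still open speak of the compounds shown alone.

Among the compounds with values here, compound 1 `CN(c1ncccc1CNc1nc(Nc2ccc3c(c2)CC(=O)N3)nc2[nH]ccc12)S(C)(=O)=O` gives the highest of the two numbers measured so far in a functional assay on SMMC-7721 cells (Homo sapiens) for inhibition, read by MTT assay, with a stated time of 48 h (on this read-out lower numbers stand for stronger inhibition and higher numbers for weaker inhibition), namely 52800 nM. Its nearest neighbour is compound 2 `Cc1c[nH]c2nc(Nc3ccc4c(c3)CC(=O)N4)nc(NCc3cccnc3N(C)S(C)(=O)=O)c12`, which in this assay gives 18700 nM; that step was a 2.8-fold lower number from compound 1 to compound 2 (0.45 log units; beyond the scatter). Compound 3 `Cc1cc2c(NCc3cccnc3N(C)S(C)(=O)=O)nc(Nc3ccc4c(c3)CC(=O)N4)nc2[nH]1` is not yet measured. It differs from compound 1 by methyl in place of hydrogen on an aromatic carbon, the new group sitting on an aromatic carbon of a five-membered aromatic ring with one nitrogen, part of a fused system of two rings, next to the ring nitrogen. Within the data shown here, the only step that bears on it is a 2.8-fold lower number from compound 1 to compound 2 (0.45 log units; beyond the scatter), where a methyl likewise replaced a hydrogen on an aromatic carbon of the shared core. On that basis a modest step downward is expected, a 1.8-fold lower number from compound 1 to compound 3 (0.25 log units; within the scatter), though a step no larger than the scatter would not surprise. Compound 3 is therefore estimated at 30000 nM, with a range from 12000 nM to 75000 nM.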

Compound 3, half-maximal inhibitory concentration: > 100000 nM
Compound 3 was reported as a limit; the forecaster's own chance of this, stated with the estimate: 5%; at least 3.3-fold (0.52 log units) between middle value and limit.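

In this assay compound 3 is reported only as a limit of the assay and not as a number: the limit of > 100000 nM in this assay, at which 1 of the 3 values shown sits.

The methyl on the aromatic carbon next to the ring nitrogen thus does not repeat the lower number that the other methyl on the shared core gave (a 2.8-fold lower number from compound 1 to compound 2 (0.45 log units; beyond the scatter)), and the step here runs the other way (an at least 1.8-fold higher number from compound 1 to compound 3 (0.27 log units; that floor lies within the scatter)). The same replacement on the same core therefore does not read out alike at every aromatic carbon of the five-membered ring, although the floor of the new step itself lies within the scatter.

On these data alone, the true size of that step stays open, as the limit gives only a floor. Also open, as far as these compounds go, is whether an ethyl, a chlorine or an amine on this carbon would follow compound 3 or compound 2.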